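The compounds below may be only part of what the source reports. "The series", "measured", "known", "first", "only" and "open" are said of these compounds alone.

Measured so far in an in vitro assay on HEK385-7 cells for displacement of a labelled ligand from prostaglandin D2 receptor 2 (Homo sapiens); a higher number here means a weaker inhibitor, a lower number a stronger inhibitor:
- compound 1 `O=C(O)Cc1sc(C(c2ccccc2)c2ccccc2)nc1-c1ccc(F)cc1`: 8.7 nM
- compound 2 `O=C(O)Cc1sc(C(c2ccccc2)c2ccccc2)nc1-c1ccc(C(F)(F)F)cc1`: 1100 nM
- compound 3 `COc1ccc(OC)c(-c2nc(C(c3ccccc3)c3ccccc3)sc2CC(=O)O)c1`: a limit only, > 105 nM

Compound 1 holds the lowest of the two numbers in this assay; the nearest is compound 2, with a 130-fold higher number from compound 1 to compound 2 (2.10 log units; beyond the scatter). Compound 3 sits at the limit of > 105 nM in this assay, at which 1 of the 3 values shown sits, so a step that the limit leaves unreadable from compound 2 to compound 3. The measured steps, a 130-fold higher number from compound 1 to compound 2 (2.10 log units; beyond the scatter) and an at least 12-fold higher number from compound 1 to compound 3 (1.08 log units; beyond the scatter), both alter the aryl group on the core of compound 1.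

Compound 4 `O=C(O)Cc1sc(C(c2ccccc2)c2ccc(F)c(F)c2)nc1-c1ccc(F)cc1` differs from compound 1 by 3,4-difluorophenyl in place of phenyl on a saturated chain carbon bound to two aromatic carbons. Within the data shown here, no measured step touches that position, so no step beyond the scatter is expected in this assay. Compound 4 is therefore estimated at 10 nM (range 3 nM to 40 nM), which means a 1.1-fold higher number from compound 1 to compound 4 (0.06 log units; within the scatter) is expected.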

Compound 4, half-maximal inhibitory concentration: 10 nM
Estimate against measurement, compound 4: no gap at the digits printed; the range from low to high includes it.
By their numbers in this assay, from the lowest: compounds 1 and 4 (each within the scatter of the next); then compound 2.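

At the saturated chain carbon bound to two aromatic carbons, 3,4-difluorophenyl in place of phenyl gives a 1.1-fold higher number from compound 1 to compound 4 (0.06 log units; within the scatter) in this assay. Among these compounds, this is the first reading at this position, and the change leaves the number in place, whereas both readable steps on the aryl group of the core of compound 1 are large. Nothing in the data shown bears on why this position differs.

Still open, from the compounds shown here alone, is whether this position accepts more than fluorine, for example an amine or a methoxy group on that phenyl. Also open, going by these compounds, is whether the second phenyl on the same carbon behaves alike.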